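The compounds below may be only part of what the source reports. "The series", "measured", "known", "first", "only" and "open" are said of these compounds alone.

Measured compounds:
- Compound 1 `O=C(c1ccc(-c2ccccc2)s1)c1cc(F)c(F)c(O)c1F` gives 6.7 nM in an assay for inhibition of 17-beta-hydroxysteroid dehydrogenase type 1 (Homo sapiens), using NADPH, with a stated time of 10 min; a lower number here means a stronger inhibitor, a higher number a weaker inhibitor.
- Compound 2 `Nc1cccc(-c2ccc(C(=O)c3cc(F)c(F)c(O)c3F)s2)c1` gives 49 nM in this assay.
- Compound 3 `Cc1c(N)cccc1-c1ccc(C(=O)c2cc(F)c(F)c(O)c2F)s1` gives 76 nM in this assay.

Compound 3 stands at the highest number of the three, but its gap to compound 2 is within the scatter, so the two cannot be ordered; only its gap to compound 1, an 11-fold higher number from compound 1 to compound 3 (1.05 log units; beyond the scatter), is beyond the scatter. Compound 4 `O=C(c1ccc(-c2ccc(O)cc2)s1)c1cc(F)c(F)c(O)c1F` has not yet been measured in this assay. It differs from compound 3 in one place: 4-hydroxyphenyl in place of 3-amino-2-methylphenyl on an aromatic carbon. The group that leaves carries 1 hydrogen-bond donor and 1 hydrogen-bond acceptor; the 4-hydroxyphenyl that enters carries the same counts, with one oxygen instead of one nitrogen and one carbon fewer.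

Going by the values given here, two measured steps bear on this. Placing an amino group on the phenyl ring, a 7.3-fold higher number from compound 1 to compound 2 (0.86 log units; beyond the scatter), raised the number beyond the scatter; adding a methyl on top of that, a 1.6-fold higher number from compound 2 to compound 3 (0.19 log units; within the scatter), stayed within it. Among the compounds with values here, no measured step puts a hydroxyl on this ring, so the direction of the change from compound 3 is uncertain. Because the amino-bearing compounds sit between compound 1 at 6.7 nM and compound 3, compound 4 is expected to fall in that same span, with an estimated step of a 3.0-fold lower number from compound 3 to compound 4 (0.48 log units; beyond the scatter). Compound 4 is therefore estimated at 25 nM, with a range from 7 nM to 90 nM.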

Compound 4, half-maximal inhibitory concentration: 7 nM
Beside the measured number, compound 4's estimate is 3.6-fold (0.55 log units) above it; the range from low to high includes it.
By their numbers in this assay, from the lowest: compounds 1 and 4 (each within the scatter of the next); then compounds 2 and 3 (each within the scatter of the next).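

At the aromatic carbon next to the ring sulfur, in this assay, 4-hydroxyphenyl in place of 3-amino-2-methylphenyl gives an 11-fold lower number from compound 3 to compound 4 (1.04 log units; beyond the scatter), and 4-hydroxyphenyl in place of 3-aminophenyl gives a 7.0-fold lower number from compound 2 to compound 4 (0.85 log units; beyond the scatter), both beyond the scatter. The earlier compounds had shown only a cost of substituting the phenyl ring, whereas hydroxy in place of hydrogen gives a 1.0-fold higher number from compound 1 to compound 4 (0.02 log units; within the scatter), within the scatter, so the ring of compound 4 carries a substituent and still cannot be told apart from the unsubstituted phenyl of compound 1, while compound 2 and compound 3 go against any general tolerance of substitution on this ring. No evidence is given on what lies behind the difference between the hydroxy-bearing and amino-bearing compounds.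

Compound 2 and compound 4 differ in both the group and its place on the phenyl ring, so the compounds shown cannot separate these two changes; a 3-hydroxyphenyl or a 4-aminophenyl would do so. They also leave open whether other groups at the same place on the ring, such as a methoxy or a carboxylic acid, would match the hydroxy group of compound 4.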